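The compounds below may be only part of what the source reports. "The series", "measured", "known", "first", "only" and "open" are said of these compounds alone.

Compound 1 `O=c1nc2oc(C3CC3)c(C#CC3CC3)c2cn1Cc1cn(-c2ccccc2F)nn1`: 49100 nM in a functional assay on SW-620 cells (Homo sapiens) for antiproliferative activity, read by MTT assay, with a stated time of 72 h; on this read-out higher numbers stand for weaker inhibition and lower numbers for stronger inhibition.
Compound 2 `CCCCCCc1cc2cn(Cc3cn(-c4ccccc4F)nn3)c(=O)nc2o1`: > 100000 nM, a limit of the assay.
Compound 3 `O=c1nc2oc(CCCCl)cc2cn1Cc1cn(-c2ccccc2F)nn1`: > 100000 nM, a limit of the assay.

Compound 3 stands in this assay only at a limit. Compound 2 sits at the same limit (the limit of > 100000 nM in this assay, at which 2 of the 3 values shown sit). The step that the two limits leave unreadable from compound 2 to compound 3 is therefore not readable in size. Compound 4 `O=c1nc2oc(CCCCl)cc2cn1Cc1cn(-c2ccc(F)cc2)nn1` differs from compound 3 by 4-fluorophenyl in place of 2-fluorophenyl on an aromatic nitrogen. Among the compounds with values here, no measured pair alters the fluorophenyl group, so no measured step bears on this change, and the two limits give no size to read from. Compound 4 is therefore expected to show no step beyond the scatter, a step that the limit leaves unreadable from compound 3 to compound 4. Compound 4 is estimated at 150000 nM, between 60000 nM and 400000 nM, with a fair chance that only a limit is reported again.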

Compound 4, half-maximal inhibitory concentration: > 100000 nM
Compound 4 gave a limit, no number; the forecaster's own chance of this, stated with the estimate: 75%; the middle value is on the limit's open side.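

Compound 3 and compound 4 both stand only at a limit in this assay, and no step can be read between them. The compounds shown leave open whether 4-fluorophenyl in place of 2-fluorophenyl changes the activity at all.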